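This account rests on a few compounds, and the source may have more. Where it says the series, first, only, none or still open, it means among the compounds named here.

Compound 1 `COc1cc(-c2nn(-c3cccc(NC(=O)Nc4cc(C(F)(F)F)cc(C(F)(F)F)c4)c3)cc2-c2ccncc2)ccc1Cl` and compound 2 `O=C(Nc1cccc(-n2cc(-c3ccncc3)c(-c3ccc(Cl)c(O)c3)n2)c1)Nc1cc(C(F)(F)F)cc(C(F)(F)F)c1` share a core and differ only in the way given by hydrogen in place of methyl on an oxygen on an aromatic ring. In a functional assay on MDA-MB-231 cells (Homo sapiens) for inhibition, read by sulforhodamine B assay, with a stated time of 48 h (a lower number here means a stronger inhibitor of growth, a higher number a weaker inhibitor of growth), compound 1 gives 1410 nM, and compound 2 gives 1660 nM; the step of a 1.2-fold higher number from compound 1 to compound 2 (0.07 log units; within the scatter) is small. Compound 3 `COc1cc(-c2nn(-c3cccc(NC(=O)Nc4ccc(Cl)c(C(F)(F)F)c4)c3)cc2-c2ccncc2)ccc1Cl` carries a different core; how its core differs from that of compound 1 is not broken down here. In this assay compound 3 gives 2600 nM, which lies within the scatter of both compound 1 and compound 2. Compound 4 `O=C(Nc1cccc(-n2cc(-c3ccncc3)c(-c3ccc(Cl)c(O)c3)n2)c1)Nc1ccc(Cl)c(C(F)(F)F)c1` is related to compound 3 by the same change, (hydrogen in place of methyl on an oxygen on an aromatic ring), with the same place and surroundings as before. Because the first instance gave only a 1.2-fold higher number from compound 1 to compound 2 (0.07 log units; within the scatter), the step of a 1.2-fold higher number from compound 3 to compound 4 (0.06 log units; within the scatter) is expected to be similarly small. Compound 4 is therefore estimated at 3000 nM, with a likely range of 1500 nM to 6000 nM.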

Compound 4, concentration for total growth inhibition: 1440 nM
Compound 4: middle estimate off by 2.1-fold (0.32 log units), on the high side, outside the stated range (below it).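

In this assay, the methoxy to hydroxy change on the second core gives a 1.8-fold lower number from compound 3 to compound 4 (0.26 log units; within the scatter). Set beside the step on the first core, the two results cannot be told apart: the same change on two cores in this assay, a 1.2-fold higher number (0.07 log units; within the scatter) from compound 1 to compound 2 and a 1.8-fold lower number (0.26 log units; within the scatter) from compound 3 to compound 4, 2.1-fold (0.33 log units) apart, within the scatter of two such steps

On these two cores, then, the change carries over with no measurable dependence on the core, and neither step can be separated from the scatter; two pairs do not show that this holds on other cores, nor do they rule out a small core-dependent difference hidden in that scatter.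

Still open, from the compounds shown here alone, is how an ethoxy, an amine or a carboxylic acid in place of the methoxy or hydroxy would read in this assay. Also open, going by these compounds, is whether the change behaves alike on cores beyond these two.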